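This account rests on a few compounds, and the source may have more. Where it says the series, first, only, none or still open, it means among the compounds named here.

Working notes on the series, read in an ADME assay for pharmacokinetics, read by LC-MS, in phosphate buffer, with a stated time of 120 min, at pH 7.4, tested at 1 uM, in the presence of a further agent that is not named here; a lower number here means that the compound disappears faster, a higher number that the compound lasts longer. Compound 1 `O=C(/C=C/CF)Nc1ccccc1` gives > 8.53 h, which is a limit of the assay and not a number. Compound 2 `CCN(CC)C/C=C/C(=O)Nc1ccccc1` gives 2.83 h, and compound 3 `O=C(/C=C/CN1CCCCC1)Nc1ccccc1` gives 2.95 h. Among the measured compounds shown here, these two are the only true numbers so far, and they lie within the scatter of each other, so compound 3 stands level with compound 2.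

The next structure is compound 4 `O=C(/C=C/CN1CCCC1)Nc1ccccc1`. The change is pyrrolidin-1-yl in place of piperidin-1-yl on a saturated chain carbon bound to a double-bonded chain carbon, with pyrrolidin-1-yl in place of piperidin-1-yl on a saturated chain carbon bound to a double-bonded chain carbon.

For the measured compounds named here, three measured steps touch this place. Two replace fluoro and start from the limit: an at least 3.0-fold lower number from compound 1 to compound 2 (0.47 log units; beyond the scatter) and an at least 2.8-fold lower number from compound 1 to compound 3 (0.46 log units; beyond the scatter). Both lie beyond the scatter, but neither swaps one nitrogen-linked group for another. Going by the values given here, the closest precedent is piperidin-1-yl in place of diethylamino, a 1.0-fold higher number from compound 2 to compound 3 (0.02 log units; within the scatter), which lies within the scatter. This is a single precedent, and no five-membered ring has been measured at this place. On that basis, no step beyond the scatter is expected in this assay.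

The estimated step is a 1.0-fold lower number from compound 3 to compound 4 (0.01 log units; within the scatter). For compound 4 the estimate is 2.9 h, with an expected range of 1.7 h to 4.8 h.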

Compound 4, half-life: 2.7 h
For compound 4 the middle estimate is 1.1-fold (0.03 log units) above the measured one; the range from low to high includes it.
By their numbers in this assay, from the lowest: compounds 4, 2 and 3 (each within the scatter of the next). At a limit, above all of these: compound 1.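

In this assay, pyrrolidin-1-yl on a saturated chain carbon bound to a double-bonded chain carbon reads level with both other nitrogen-linked groups: a 1.1-fold lower number from compound 3 to compound 4 (0.04 log units; within the scatter) and a 1.0-fold lower number from compound 2 to compound 4 (0.02 log units; within the scatter). Among compound 2, compound 3 and compound 4, this place therefore shows no separation on going from the six-membered ring to the five-membered ring, or from either ring to the open diethylamino group. Pyrrolidin-1-yl in place of fluoro gives an at least 3.1-fold lower number from compound 1 to compound 4 (0.49 log units; beyond the scatter), which makes this the third nitrogen-linked group to stand beyond the scatter from compound 1, but the value of compound 1 is a limit and not a number, so the full size of this step stays unknown: the limit of > 8.53 h in this assay, at which 1 of the 4 values shown sits.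

The compounds shown leave open whether the level reading would hold for a ring with a further hetero atom, such as morpholin-4-yl, or for an unsubstituted primary amine at this place. They also leave open how a longer chain carrying the same amines would read in this assay.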